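A few compounds are considered here, and "the series" means these few. Any claim that something is new, unique, unknown or untested is made for them only; others in the source may bear on it.

Of the compounds shown here, three have been tested in a functional assay on HepG2 cells (Homo sapiens) for antiproliferative activity, read by CCK-8 assay, with a stated time of 72 h, tested at 8 uM; on this read-out higher numbers stand for a stronger effect at the one concentration tested and lower numbers for a weaker effect. Compound 1 `CN1CCN(c2nc(Cl)nc3c2ncn3Cc2ccc(C(=O)Nc3ccccc3N)cc2)CC1` carries a 4-methylpiperazin-1-yl group on its core and gives 75%. Compound 2 `CC(C)n1cnc2c(Nc3cccc(Cl)c3)nc(NCOCc3ccc(C(=O)Nc4ccccc4N)cc3)nc21`, built on a related but not identical core, gives 60.5%. Compound 3 `Nc1ccccc1NC(=O)c1ccc(Cn2cnc3c(Nc4cccc(OC(F)(F)F)c4)nc(Cl)nc32)cc1` gives 31.2%, the weakest of the three: its distance to each of the others lies beyond the usual scatter. Among the measured compounds shown here, the one measured step that reaches it, a number 43.8 percentage points lower from compound 1 to compound 3 (beyond the scatter), shows that the anilino-type group in compound 3 costs a great deal against the piperazine of compound 1.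

Compound 4 `Cc1ccc(Nc2nc(Cl)nc3c2ncn3Cc2ccc(C(=O)Nc3ccccc3N)cc2)cc1` keeps the core of compound 3 and changes only the group on the ring nitrogen: 4-methylphenyl in place of 3-(trifluoromethoxy)phenyl on a nitrogen on an aromatic ring. For the measured compounds named here, no measured step compares two such aryl groups on this core, so the expectation rests on weak ground. Compound 2, with a chlorophenylamino group on a different core, sits well above compound 3, which leaves some room for an increase. Compound 4 is therefore expected to show a modest rise, a number 8.8 percentage points higher from compound 3 to compound 4 (within the scatter), landing at about 40%, with a likely range from 20% to 62%.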

Compound 4, a percentage reported as inhibition, at one concentration (the size of the read-out at that concentration, not a potency): 82%
For compound 4 the middle estimate is 42 percentage points below the measured one, outside the stated range (above it).
By their numbers in this assay, from the lowest: compound 3; then compound 2; then compounds 1 and 4 (each within the scatter of the next).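

In this assay, among the compounds shown here, the choice of aryl group on this nitrogen matters far more than the earlier compounds could show: with the rest of the molecule unchanged, 4-methylphenyl in place of 3-(trifluoromethoxy)phenyl gives a number 50.8 percentage points higher from compound 3 to compound 4 (beyond the scatter). The earlier drop from the piperazine therefore cannot be charged to every arylamino group, since a number 7 percentage points higher from compound 1 to compound 4 (within the scatter) leaves (4-methylphenyl)amino and 4-methylpiperazin-1-yl indistinguishable on this read-out. No measurement at hand says why these two aryl groups behave so differently.

Still open, from the compounds shown here alone, is whether the change in activity follows the loss of the trifluoromethoxy group, the gain of the methyl group, or the different place of the substituent on the ring, as all three change together in this one step. A plain phenyl, a 3-methylphenyl or a 4-(trifluoromethoxy)phenyl group on the same nitrogen could separate these.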